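The source may hold more compounds than are shown below. What is called first, only, known or untested is meant among the compounds shown, and "the series" means these compounds.

Measured compounds in an assay on cells (strain Sprague-Dawley) for inhibition of Polyunsaturated fatty acid 5-lipoxygenase (Rattus norvegicus), with a stated time of 30 min; a higher number here means a weaker inhibitor, a lower number a stronger inhibitor:
- compound 1 `CC(=O)Oc1ccc(/C=C/C(=O)OCCCSc2nc(-c3ccc(S(N)(=O)=O)cc3)n(-c3ccc(F)cc3)n2)cc1OC(C)=O`: compound 1 gives 1030 nM
- compound 2 `CS(=O)(=O)c1ccc(-c2nc(SCCOC(=O)/C=C/c3ccc(O)c(O)c3)nn2-c2ccccc2)cc1`: compound 2 gives 850 nM
- compound 3 `NS(=O)(=O)c1ccc(-c2nc(SCCOC(=O)/C=C/c3ccc(O)c(O)c3)nn2-c2ccccc2)cc1`: compound 3 gives 800 nM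

Compound 2 holds the second highest of the three numbers. Its nearest neighbour is compound 3, reached by a 1.1-fold lower number from compound 2 to compound 3 (0.03 log units; within the scatter), a change of amino in place of methyl on a sulfonyl sulfur. Compound 1 differs from compound 2 in more than one place; its value and that of compound 2 lie within the usual scatter of each other, so the two numbers show no separation.

Compound 4 `COc1cc(/C=C/C(=O)OCCSc2nc(-c3ccc(S(C)(=O)=O)cc3)n(-c3ccccc3)n2)ccc1O` differs from compound 2 by methyl in place of hydrogen on an oxygen on an aromatic ring. Among the compounds with values here, no measured step touches this oxygen: the only step in hand, a 1.1-fold lower number from compound 2 to compound 3 (0.03 log units; within the scatter), concerns the sulfonyl sulfur and is itself within the scatter. Nothing in the series therefore points to a shift in this assay beyond the scatter in either direction. The expected step is a 1.3-fold higher number from compound 2 to compound 4 (0.11 log units; within the scatter). For compound 4 the estimate is 1100 nM, with an expected range from 450 nM to 2700 nM.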

Compound 4, half-maximal inhibitory concentration: 840 nM
Beside the measured number, compound 4's estimate is 1.3-fold (0.12 log units) above it; low and high end bracket the measured number.
By their numbers in this assay, from the lowest: compounds 3, 4, 2 and 1 (each within the scatter of the next).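

In this assay, within the data shown here, the change from 3,4-dihydroxyphenyl to 4-hydroxy-3-methoxyphenyl gives a 1.0-fold lower number from compound 2 to compound 4 (0.01 log units; within the scatter), the only measured step at this oxygen. In this pair, one of the two hydroxy groups therefore carries a methyl without the number leaving the scatter. Alongside a 1.1-fold lower number from compound 2 to compound 3 (0.03 log units; within the scatter), this means that neither single change shown separates from compound 2 in this assay.

No measurement at hand offers an explanation for this flat result. Still open is whether a benzyl or ethyl group on this oxygen, or an amine in place of the hydroxy, would also stay within the scatter of compound 2, since methyl is the only single change shown at this position.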